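Prostaglandin F2-alpha ligands: 4-methoxyphenyl tail variant

A few compounds are considered here, and "the series" means these few. Any claim that something is new, unique, unknown or untested is made for them only; others in the source may bear on it.

In an in vitro assay on CHO-KI cells for displacement of a labelled ligand from prostaglandin F2-alpha receptor (Homo sapiens) (on this read-out higher numbers stand for weaker inhibition and lower numbers for stronger inhibition), compound 1 `O=C(O)CCCCCC[C@@H]1[C@@H](CC[C@@H](O)CCc2ccc(F)cc2)[C@H](O)C[C@@H]1O` gives 210 nM and compound 2 `Cc1ccccc1CC[C@H](O)CC[C@@H]1[C@@H](CCCCCCC(=O)O)[C@@H](O)C[C@H]1O` gives 630 nM. For the measured compounds named here, compound 2 thus stands at the highest of the two numbers in this assay, its nearest neighbour being compound 1, with a 3.0-fold higher number from compound 1 to compound 2 (0.48 log units; beyond the scatter) bringing the only measured step.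

Compound 3 `COc1ccc(CC[C@H](O)CC[C@@H]2[C@@H](CCCCCCC(=O)O)[C@@H](O)C[C@H]2O)cc1` has not yet been measured. It differs from compound 2 by 4-methoxyphenyl in place of 2-methylphenyl on a saturated chain carbon, three bonds along the chain from an oxygen on a saturated carbon.

The step from compound 1 to compound 2 is the only one that bears on this change, and it touches the same aryl group on the same chain carbon. It went from 4-fluorophenyl to 2-methylphenyl and read modest, beyond the scatter. Going by the values given here, the change to compound 3 moves away from 2-methylphenyl again, toward a 4-substituted phenyl as in compound 1, so a modest step back toward the number of compound 1 is expected in this assay, though no measured pair shows 4-methoxyphenyl itself.

Compound 3 is estimated at 280 nM in this assay, with a range from 110 nM to 750 nM, meaning an expected step of a 2.3-fold lower number from compound 2 to compound 3 (0.35 log units; beyond the scatter).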

Compound 3, half-maximal inhibitory concentration: 290 nM
Beside the measured number, compound 3's estimate is 1.0-fold (0.02 log units) below it; low and high end bracket the measured number.
By their numbers in this assay, from the lowest: compounds 1 and 3 (each within the scatter of the next); then compound 2.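

In this assay the change to 4-methoxyphenyl brings a 2.2-fold lower number from compound 2 to compound 3 (0.34 log units; beyond the scatter) and so gives this chain carbon a third aryl group, showing that the number of compound 2 is not common to every substituted phenyl placed here. With a 1.4-fold higher number from compound 1 to compound 3 (0.14 log units; within the scatter) as the methoxy in place of fluoro on an aromatic carbon, 4-fluorophenyl and 4-methoxyphenyl cannot be told apart on this read-out, while 2-methylphenyl stands apart from both, its steps to each lying beyond the scatter. Nothing at hand accounts for that separation or for the two groups reading alike.

From the compounds shown here alone, it remains open whether the number of compound 2 follows from the methyl group itself or from where that group sits on the ring, and compounds carrying 4-methylphenyl or 2-methoxyphenyl on the same chain carbon would separate those two readings. Also open, going by these compounds, is whether the agreement between fluoro and methoxy extends to other groups in that place, such as chloro or a plain unsubstituted phenyl.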